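The source may hold more compounds than are shown below. What is called first, only, known or untested is meant among the compounds shown, and "the series" means these compounds.

Measured in a functional assay (plasma) for inhibition, with Homo sapiens as the target; a higher number here means a weaker inhibitor, a lower number a stronger inhibitor:
- Compound 1 `NCc1ccc(Cn2cnc3cc(C(=O)NCCC(=O)O)ccc32)cc1`: 83000 nM
- Compound 2 `CCCCOC(=O)N[C@@H](CNC(=O)c1ccc2nc(-c3ccc(C(=N)N)cc3)oc2c1)C(=O)O`: 20 nM
- Compound 3 `CCCCOC(=O)N[C@@H](CNC(=O)c1ccc2[nH]c(-c3ccc(C(=N)N)cc3)nc2c1)C(=O)O`: 50 nM

Compound 1 has the highest number of the three, well beyond the scatter from both others, which makes it the weakest inhibitor here. Compound 4 `N=C(N)c1ccc(Cn2cnc3cc(C(=O)NCCC(=O)O)ccc32)cc1` keeps the core of compound 1 and changes one group, on an aromatic carbon of a six-membered aromatic ring of carbon only, para to a large group: a group of 3 heavy atoms (1 carbon, 2 nitrogen; no ring) in place of a group of 2 heavy atoms (1 carbon, 1 nitrogen; no ring), on an aromatic carbon. Among the measured compounds shown here, compounds 2 and 3 carry the same entering group but differ elsewhere too, so no measured pair isolates this change. A clear fall in the number is expected, with the size estimated as a 28-fold lower number from compound 1 to compound 4 (1.44 log units; beyond the scatter). That fall is not expected to be as large as the gaps to compounds 2 and 3. For compound 4 the estimated value is 3000 nM, with a range of 400 nM to 20000 nM.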

Compound 4, half-maximal inhibitory concentration: 6800 nM
Estimate against measurement, compound 4: 2.3-fold (0.36 log units) below, within the range that was stated.
By their numbers in this assay, from the lowest: compound 2; then compound 3; then compound 4; then compound 1.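

In this assay, replacing aminomethyl with the group of 3 heavy atoms on an aromatic carbon, para to a large group, gives a 12-fold lower number from compound 1 to compound 4 (1.09 log units; beyond the scatter). Among the compounds shown here, this pair is the first to isolate the change, and it shows that on the core of compound 1 this single replacement is enough for a large step beyond the scatter. Nothing available explains the size of this step. From the compounds shown here alone, whether a nitrile or a longer amine chain at this position would lower the number further remains open. Also open, going by these compounds, is whether the same replacement would give a similar step on another core.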